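Series notes: aryl replacement on the chain carbon

A few compounds are considered here, and "the series" means these few. Any claim that something is new, unique, unknown or untested is made for them only; others in the source may bear on it.

Measured so far:
compound 1, `C=CCCC1COC2(C=CC(=O)C=C2)N(c2ccccc2)C1=O`: in a functional assay on BV-2 cells (Mus musculus), read by Griess assay, with a stated time of 24 h (a higher number here means a weaker inhibitor, a lower number a stronger inhibitor), compound 1 gives 730 nM
compound 2, `O=C1C=CC2(C=C1)OCC(Cc1cccc(Br)c1)C(=O)N2c1ccccc1`: in this assay compound 2 gives 540 nM

Among the measured compounds shown here, compound 2 has the lowest of the two numbers so far, but the only step that reaches it, a 1.4-fold lower number from compound 1 to compound 2 (0.13 log units; within the scatter), lies within the scatter, so no order between compound 1 and compound 2 can be read from these values.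

Compound 3, `Cc1cc(C)cc(CC2COC3(C=CC(=O)C=C3)N(c3ccccc3)C2=O)c1`, is the next in the series. The change from compound 2 is 3,5-dimethylphenyl in place of 3-bromophenyl on a saturated chain carbon bound to a saturated ring carbon. For the measured compounds named here, the one measured step that bears on this position is the exchange of allyl for 3-bromophenyl, a 1.4-fold lower number from compound 1 to compound 2 (0.13 log units; within the scatter), which was within the scatter. Two different groups on the same saturated chain carbon have thus given numbers within scatter of each other, and nothing shown singles out the 3,5-dimethylphenyl group. No step beyond the scatter is therefore expected in this assay in either direction.

Compound 3 is expected to give 600 nM, with a range of 250 nM to 1400 nM. The expected step is a 1.1-fold higher number from compound 2 to compound 3 (0.05 log units; within the scatter), within the scatter.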

Compound 3, half-maximal inhibitory concentration: 1820 nM
Compound 3: middle estimate off by 3.0-fold (0.48 log units), on the low side; the whole stated range lies below it.
By their numbers in this assay, from the lowest: compounds 2 and 1 (each within the scatter of the next); then compound 3.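

In this assay the group on this saturated chain carbon does set the number: 3,5-dimethylphenyl in place of 3-bromophenyl gives a 3.4-fold higher number from compound 2 to compound 3 (0.53 log units; beyond the scatter) and 3,5-dimethylphenyl in place of allyl gives a 2.5-fold higher number from compound 1 to compound 3 (0.40 log units; beyond the scatter) with both steps beyond the scatter. The earlier step had shown only allyl and 3-bromophenyl within the scatter of each other, whereas an exchange of one aryl group for another now moves the number beyond it, so carrying an aryl group at this position does not by itself fix the result. Nothing measured here accounts for the step from 3-bromophenyl to 3,5-dimethylphenyl.

Going by these compounds, it remains open whether the step follows the loss of the bromine or the arrival of the methyl groups, which unsubstituted phenyl or 3-methylphenyl on the same carbon would separate. Also open, on these data alone, is how 3,5-dibromophenyl or a longer chain between the aryl ring and the core would read.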